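A few compounds are considered here, and "the series" means these few. Any claim that something is new, unique, unknown or untested is made for them only; others in the source may bear on it.

Measured compounds:
- compound 1, `O=C(/C=C\Nc1ccc(Cl)cc1)c1cn(-c2ccccc2)nc1-c1ccc(Cl)cc1`, in an ADME assay on HaCaT cells (Homo sapiens) for antiproliferative activity, read by MTT assay, with a stated time of 48 h (a higher number here means a weaker inhibitor, a lower number a stronger inhibitor), compound 1 gives 23400 nM
- compound 2, `COc1ccc(-c2nn(-c3ccccc3)cc2C(=O)/C=C\Nc2ccc(F)cc2)cc1`, in this assay compound 2 gives 8910 nM

Of the two numbers seen so far, compound 2 has the lower one, and the gap to compound 1 is wide enough to count as a real difference rather than scatter. The two compounds differ in more than one place, so what sets them apart cannot be traced to a single change.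

Compound 3, `COc1ccc(-c2nn(-c3ccccc3)cc2C(=O)/C=C\Nc2ccc(Cl)cc2)cc1`, is the next compound to be tested. It keeps everything in compound 2 except one substituent: chloro in place of fluoro on an aromatic carbon. The replaced atom sits on the outer ring that carries the amino group, para to a large group, and the swap exchanges one halogen for a slightly larger one. Within the data shown here, nothing in the measured pair isolates this particular exchange, so there is no measured step to lean on. A swap of this size on a peripheral ring is expected to move the number little, and the step from compound 2 to compound 3 is estimated at a 1.1-fold higher number from compound 2 to compound 3 (0.05 log units; within the scatter), most likely within the scatter. Compound 3 is therefore expected to land near 10000 nM, somewhere between 4000 nM and 25000 nM.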

Compound 3, half-maximal inhibitory concentration: 20900 nM
For compound 3 the middle estimate is 2.1-fold (0.32 log units) below the measured one, and the stated range covers the measured number.
By their numbers in this assay, from the lowest: compound 2; then compounds 3 and 1 (each within the scatter of the next).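

In this assay, the halogen on the outer ring that carries the amino group does register: chloro in place of fluoro on an aromatic carbon, para to a large group, gives a 2.3-fold higher number from compound 2 to compound 3 (0.37 log units; beyond the scatter) and so exchanges one atom for a modest but real difference. The other comparison concerns a different place on the molecule, where methoxy in place of chloro on an aromatic carbon gives a 1.1-fold lower number from compound 1 to compound 3 (0.05 log units; within the scatter) and so shows no real difference while chloro sits on the amino-bearing ring. No independent measurement bears on the reason for either result.

The compounds shown leave open how other groups at the amino-bearing ring's para place would read, such as a bare hydrogen, a nitrile or an amine, since only fluoro and chloro appear there. Among these compounds, they also leave open whether the exchange of fluoro for chloro would give a step of similar size with chloro rather than methoxy on the other outer ring, because the one step available comes from a single pair of compounds.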